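Chloro on the phenyl arm: expected inhibition for compound 3

A few compounds are considered here, and "the series" means these few. Any claim that something is new, unique, unknown or untested is made for them only; others in the source may bear on it.

Measured so far:
compound 1, `CCCNC(=O)NS(=O)(=O)c1ccc(-n2nc(-c3ccccc3)ccc2=O)cc1`, 125%
compound 2, `O=C(NC1CCCCC1)NS(=O)(=O)c1ccc(-n2nc(-c3ccccc3)ccc2=O)cc1`, 86.2%

Going by the values given here, in a functional assay on the whole organism (blood, strain Wistar albino) for inhibition, with Rattus norvegicus as the target, read by colorimetric assay, with stated times of 15 min and 90 min, at a dose of 20 mg/kg by the oral route (a higher number here means more inhibition at the dose given (going by the name of the read-out), a lower number less inhibition), compound 1 gives 125%, the highest of the two numbers measured so far. Compound 2 `O=C(NC1CCCCC1)NS(=O)(=O)c1ccc(-n2nc(-c3ccccc3)ccc2=O)cc1` gives 86.2% in this assay. Among the compounds with values here, the single measured step, a number 38.8 percentage points lower from compound 1 to compound 2 (beyond the scatter), changes only the group on the amide-type nitrogen and leaves the phenyl arm untouched.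

Compound 3 `CCCNC(=O)NS(=O)(=O)c1ccc(-n2nc(-c3ccc(Cl)cc3)ccc2=O)cc1` differs from compound 1 at a different place: chloro in place of hydrogen on an aromatic carbon. Within the data shown here, no measured step involves this aromatic carbon or any substituent on the phenyl arm, so the measured data give no direction for this change; the propyl urea side of compound 1 is retained unchanged in compound 3.

In the absence of a comparable step, compound 3 is estimated at 118%, with a range from 92% to 140%. The expected step, a number 7 percentage points lower from compound 1 to compound 3 (within the scatter), is estimated to lie within the scatter.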

Compound 3, a percentage reported as inhibition, in the whole organism at one dose (the size of the read-out at that dose, not a potency): 122%
For compound 3 the middle estimate is 4 percentage points below the measured one, within the range that was stated.
By their numbers in this assay, from the lowest: compound 2; then compounds 3 and 1 (each within the scatter of the next).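

In this assay the phenyl arm now has its first measured step, a number 3 percentage points lower from compound 1 to compound 3 (within the scatter), so compound 1 and compound 3 cannot be told apart at this dose. Chloro on the aromatic carbon para to a large group therefore keeps the read-out at the level of compound 1, whereas the only step beyond the scatter remains the one on the amide-type nitrogen, a number 38.8 percentage points lower from compound 1 to compound 2 (beyond the scatter). No available evidence bears on why the phenyl to 4-chlorophenyl change has so small an effect.

As far as these compounds go, whether chloro at this place would also leave the read-out within the scatter with cyclohexyl on the amide-type nitrogen remains open. So does the outcome for a methoxy group or an amine at the same place on the phenyl arm.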